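A few compounds are considered here, and "the series" means these few. Any claim that something is new, unique, unknown or untested is made for them only; others in the source may bear on it.

Compound 1 `Nc1ccn([C@H]2C[C@H](O)[C@@](/C=C/Cl)(CO)O2)c(=O)n1` is a nucleoside whose sugar carries a 2-chloroethenyl group on a saturated ring carbon. In a functional assay on KB cells (Homo sapiens) for cytotoxicity (on this read-out lower numbers stand for stronger inhibition and higher numbers for weaker inhibition), compound 1 gives only a limit, > 350000 nM, and no number. Compound 2 `N#C[C@]1(CO)O[C@@H](n2ccc(N)nc2=O)C[C@@H]1O` carries a cyano group at the same position. In this assay compound 2 likewise gives only a limit, > 350000 nM. Among the compounds with values here, the step from compound 1 to compound 2 is therefore a step that the two limits leave unreadable from compound 1 to compound 2, and it is the sole measured step touching this place; as the limit of > 350000 nM in this assay, at which 2 of the 2 values shown sit, notes, both values shown sit at that limit. Compound 3 `C[C@]1(CO)O[C@@H](n2ccc(N)nc2=O)C[C@@H]1O` differs from compound 1 by methyl in place of 2-chloroethenyl on a saturated ring carbon. With both neighbours at the assay limit, no direction can be read for this exchange, and compound 3 is expected to give a limit or a weak value as well. The step from compound 1 to compound 3 is estimated as a step that the limit leaves unreadable from compound 1 to compound 3. For compound 3 the estimate in this assay is 500000 nM, within a range from 100000 nM to 2000000 nM.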

Compound 3, half-maximal inhibitory concentration: > 350000 nM
Compound 3 was reported as a limit; the forecaster's own chance of this, stated with the estimate: 85%; the middle value does not contradict the limit.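

In this assay, within the data shown here, compound 3 gives only a limit, > 350000 nM, so no step linking it to compound 1 or compound 2 can be read: the limit of > 350000 nM in this assay, at which 3 of the 3 values shown sit. The compounds shown leave open whether the group at this place affects cytotoxicity at all, and in which direction.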